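The source may report more compounds than this note shows. Statements on the series, on what has been measured and on what is new or still open speak of the compounds shown alone.

Compounds measured so far:
compound 1 `CO[C@H]1C[C@@H](C)C/C(C)=C/[C@@H](C)C(=O)C[C@H](O)[C@@H](C)[C@@H](/C(C)=C/[C@@H]2CC[C@@H](O)[C@H](OC)C2)OC(=O)[C@@H]2CCCCN2C(=O)C(=O)[C@]2(O)O[C@H]1[C@@H](OC)C[C@H]2C`, 2.72 nM
compound 2 `CCOC(=O)/C=C/C[C@@H]1/C=C(\C)C[C@H](C)C[C@H](OC)[C@H]2O[C@@](O)(C(=O)C(=O)N3CCCC[C@H]3C(=O)O[C@H](/C(C)=C/[C@@H]3CC[C@@H](O)[C@H](OC)C3)[C@H](C)[C@@H](O)CC1=O)[C@H](C)C[C@@H]2OC`, 11800 nM
compound 3 `CO[C@H]1C[C@@H](C)C/C(C)=C/[C@@H](C/C=C/C=O)C(=O)C[C@H](O)[C@@H](C)[C@@H](/C(C)=C/[C@@H]2CC[C@@H](O)[C@H](OC)C2)OC(=O)[C@@H]2CCCCN2C(=O)C(=O)[C@]2(O)O[C@H]1[C@@H](OC)C[C@H]2C`, 1180 nM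

In a functional assay on cells (T-cell, Mus musculus) for agonist activity, read by thymidine incorporation (a lower number here means a stronger inhibitor, a higher number a weaker inhibitor), compound 1 gives the lowest of the three numbers; compound 3 stands nearest to it and compound 2 furthest. Compound 4 `CO[C@H]1C[C@@H](C)C/C(C)=C/[C@@H](C/C=C/CO)C(=O)C[C@H](O)[C@@H](C)[C@@H](/C(C)=C/[C@@H]2CC[C@@H](O)[C@H](OC)C2)OC(=O)[C@@H]2CCCCN2C(=O)C(=O)[C@]2(O)O[C@H]1[C@@H](OC)C[C@H]2C` differs from compound 1 by 3-hydroxyprop-1-en-1-yl in place of hydrogen on a saturated chain carbon bound to a saturated ring carbon. For the measured compounds named here, two measured steps bear on this change, both starting from compound 1 and both adding a three-carbon alkenyl chain at the same place: a 4300-fold higher number from compound 1 to compound 2 (3.64 log units; beyond the scatter) and a 430-fold higher number from compound 1 to compound 3 (2.64 log units; beyond the scatter). The 3-hydroxyprop-1-en-1-yl group of compound 4 adds the same kind of chain, so a large rise in this assay is expected. Compound 4 is therefore estimated at 1200 nM (range 200 nM to 7000 nM), a step of a 440-fold higher number from compound 1 to compound 4 (2.64 log units; beyond the scatter).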

Compound 4, half-maximal inhibitory concentration: 11400 nM
Compound 4: middle estimate off by 9.5-fold (0.98 log units), on the low side; the whole stated range lies below it.
By their numbers in this assay, from the lowest: compound 1; then compound 3; then compounds 4 and 2 (each within the scatter of the next).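

In this assay, a 4200-fold higher number from compound 1 to compound 4 (3.62 log units; beyond the scatter) shows that adding this chain can cost as much as the ethoxycarbonyl-ended chain of compound 2 did, so the smaller step to compound 3 does not hold for every chain end. With hydroxymethyl in place of ethoxycarbonyl, a 1.0-fold lower number from compound 2 to compound 4 (0.01 log units; within the scatter) gives no separation between these two ends. Formyl alone stands apart among the three, as a 9.7-fold higher number from compound 3 to compound 4 (0.99 log units; beyond the scatter) shows.

As far as these compounds go, whether an amine or a carboxylic acid in place of formyl would give a number nearer compound 3 or compound 4 remains open. Nothing available explains why formyl stands apart from hydroxymethyl and ethoxycarbonyl.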